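Para-substituted benzyl series: chloro to trifluoromethyl

This account rests on a few compounds, and the source may have more. Where it says the series, first, only, none or still open, it means among the compounds named here.

Measured so far:
- compound 1 `O=C1CCC(Cc2ccc(Cl)cc2)C(=O)N1` - 137 mg/kg
- compound 2 `O=C1CCC(Cc2ccc(Br)cc2)C(=O)N1` - 279 mg/kg

Among the compounds with values here, in a functional assay on the whole organism with Mus musculus as the target, in the maximal electroshock model (on this read-out lower numbers stand for an effect already at smaller amounts and higher numbers for an effect only at larger amounts of compound), compound 1 gives 137 mg/kg as the lower of the two numbers so far. Compound 3 `O=C1CCC(Cc2ccc(C(F)(F)F)cc2)C(=O)N1` is not yet measured and departs from compound 1 by one change: trifluoromethyl in place of chloro on an aromatic carbon. Within the data shown here, only one measured step bears on this, the replacement of the same chloro by bromo, and it is modest but beyond the scatter: a 2.0-fold higher number from compound 1 to compound 2 (0.31 log units; beyond the scatter) in this assay. Among the measured compounds shown here, one step sets no trend, and no compound with trifluoromethyl has been measured. A step of about that size or smaller, toward a higher number, is therefore expected. The expected step is a 1.5-fold higher number from compound 1 to compound 3 (0.19 log units; within the scatter) as a working figure. Compound 3 is estimated at 210 mg/kg with an expected range from 90 mg/kg to 480 mg/kg for now.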

Compound 3, dose for half-maximal effect: 126 mg/kg
For compound 3 the middle estimate is 1.7-fold (0.22 log units) above the measured one; measured number inside the range.
By their numbers in this assay, from the lowest: compounds 3 and 1 (each within the scatter of the next); then compound 2.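

In this assay, trifluoromethyl, with 4 heavy atoms entering where chloro had 1, leaves the number in the same range as chloro on this aromatic carbon (a 1.1-fold lower number from compound 1 to compound 3 (0.04 log units; within the scatter)). Bromo now stands apart from both other groups, since trifluoromethyl also differs from it beyond the scatter (a 2.2-fold lower number from compound 2 to compound 3 (0.35 log units; beyond the scatter)), so more heavy atoms at this place do not by themselves bring a higher number. Nothing measured here accounts for the separate position of bromo.

Open, as far as these compounds go, is whether an amine, a carboxylic acid or a longer chain at this place would stay in the range of compound 1 and compound 3 or move with compound 2. Also open, from the compounds shown here alone, is whether the same order of chloro, bromo and trifluoromethyl would hold on a core other than the one shared here.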